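Homologation on the pyrazole core and hydroxyacid oxidase binding

The source may report more compounds than this note shows. Statements on the series, on what has been measured and on what is new or still open speak of the compounds shown alone.

Measured compounds:
compound 1 `Cc1c(Cc2cccc(-c3ccc(F)cc3)c2)c(C(=O)O)nn1C`, 2%
compound 2 `Cc1n[nH]c(C(=O)O)c1Cc1cccc(C(=O)O)c1`, 3%
compound 3 `CCc1n[nH]c(C(=O)O)c1Cc1cccc(-c2ccc(F)cc2)c1`, 5%

In an assay on isolated protein for inhibition of 2-Hydroxyacid oxidase 2 (Homo sapiens), tested at 1 uM (a higher number here means a stronger effect of the compound at the concentration tested, a lower number a weaker effect), compound 3 gives 5%. That number lies within the usual scatter of compound 2 and of compound 1, so the three measured compounds are not separated from one another by this assay; all sit near the bottom of the read-out.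

Compound 4 `CC(C)c1n[nH]c(C(=O)O)c1Cc1cccc(-c2ccc(F)cc2)c1` is not yet measured. It differs from compound 3 in one place: methyl in place of hydrogen on a saturated chain carbon bound to an aromatic carbon and a saturated chain carbon.

Among the compounds with values here, no pair of measured compounds differs in only one place, so nothing here tells how such a change moves the number. Since compound 3 gives 5%, and the other two compounds show nothing different, no step beyond the scatter is expected in either direction. The expected step of no change at the digits printed from compound 3 to compound 4 (within the scatter) is essentially flat. Compound 4 is estimated at 5%, within a range of 0% to 15%.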

Compound 4, a percentage reported as inhibition, at one concentration (the size of the read-out at that concentration, not a potency): 2%
Compound 4: the middle estimate sits 3 percentage points above what was measured; the range from low to high includes it.
By their numbers in this assay, from the lowest: compounds 1, 4, 2 and 3 (each within the scatter of the next).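

In this assay, within the data shown here, methyl in place of hydrogen on this saturated chain carbon, which turns ethyl into isopropyl, gives the first comparison in one place (a number 3 percentage points lower from compound 3 to compound 4 (within the scatter)). At this position, then, the change does not separate the two compounds, and both stay near the bottom of the read-out. No measurement shown offers an explanation for this result.

Still open, going by these compounds, is whether a longer chain or an amine at this position would move the number beyond the scatter. On these data alone, with compounds this close to the bottom of the read-out, the effect of this change on a more strongly inhibiting compound also remains unknown.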